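The source may hold more compounds than are shown below. What is called first, only, known or untested is meant among the compounds shown, and "the series" means these compounds.

Measured compounds:
- compound 1 `Cc1noc(C)c1-c1cnc(N)c(Oc2ccc(C(=O)Nc3ncccc3Cl)cc2)n1`: 45600 nM
- compound 2 `Cn1cc(-c2cnc(N)c(Oc3ccc(C(=O)Nc4cccc(Cl)c4)cc3)n2)cn1`: 21700 nM

Both compounds were tested in a functional assay on U-87MG ATCC cells for inhibition, with U-87 MG (Homo sapiens) as the target, read by MTT assay, with a stated time of 72 h; on this read-out lower numbers stand for stronger inhibition and higher numbers for weaker inhibition. Compound 1 gives 45600 nM. Compound 2 gives 21700 nM, the lower of the two numbers; the gap between compound 2 and compound 1 is beyond the usual scatter of this assay. The two compounds differ in more than one place, so nothing can be said about which of those changes accounts for the gap.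

Compound 3 `Cn1cc(-c2cnc(N)c(Oc3ccc(C(=O)Nc4ncccc4Cl)cc3)n2)cn1` has not yet been measured. It is derived from compound 2 by one change: 3-chloropyridin-2-yl in place of 3-chlorophenyl on an amide-type nitrogen. The same amide group, with the pyridine nitrogen, is already present in compound 1, where it sits next to a different heteroaryl ring on the shared core, and compound 1 is the weaker of the two measured compounds. With only these two compounds to go by, the step is expected to be small and, if anything, towards a higher number, possibly within the scatter. The estimated step from compound 2 to compound 3 in this assay is a 1.5-fold higher number from compound 2 to compound 3 (0.17 log units; within the scatter). Compound 3 is therefore expected to give about 32000 nM, with a plausible range from 12000 nM to 85000 nM.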

Compound 3, half-maximal inhibitory concentration: 37600 nM
For compound 3 the middle estimate is 1.2-fold (0.07 log units) below the measured one; the range from low to high includes it.
By their numbers in this assay, from the lowest: compounds 2, 3 and 1 (each within the scatter of the next, the first and the last beyond it).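

In this assay, 3-chloropyridin-2-yl in place of 3-chlorophenyl on an amide-type nitrogen gives a 1.7-fold higher number from compound 2 to compound 3 (0.24 log units; within the scatter), so adding a ring nitrogen, and with it one hydrogen-bond acceptor, does not shift the read-out beyond the usual scatter at this position. With that amide group held constant, 1-methyl-1H-pyrazol-4-yl in place of 3,5-dimethyl-1,2-oxazol-4-yl on an aromatic carbon gives a 1.2-fold lower number from compound 1 to compound 3 (0.08 log units; within the scatter), so this second change also stays within the scatter. The gap between compound 1 and compound 2, which could not be assigned to either change before, now resolves into two single steps, neither of which lies beyond the scatter on its own.

No independent measurement is available to explain why either step is this small. Still open, as far as these compounds go, is whether a different group on the amide-type nitrogen, such as an unsubstituted phenyl or a pyridine carrying an amine in place of the chlorine, would produce a step beyond the scatter in this assay.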